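Pyridin-2-yl in place of 1-methyl-1H-imidazol-4-yl

A few compounds are considered here, and "the series" means these few. Any claim that something is new, unique, unknown or untested is made for them only; others in the source may bear on it.

Three close relatives have been measured so far in a physicochemical assay for lipophilicity; a higher number here means a more lipophilic compound, a lower number a more polar compound. Compound 1 `Cc1cc(Cl)c(-c2cn(C)cn2)cc1NC(=O)c1ccc(OCc2ccccn2)cc1` gives 3.1, compound 2 `Cc1cc(Cl)c(-c2cn(C)c(C)n2)cc1NC(=O)c1ccc(OCc2ccccn2)cc1` gives 3.3, and compound 3 `Cc1cc(C)c(-c2cn(C)cn2)cc1NC(=O)c1ccc(OCc2ccccn2)cc1` gives 3. These numbers all lie within the usual scatter of one another, so compound 3 cannot be told apart from its two neighbours.

Compound 4 `Cc1cc(C)c(-c2ccccn2)cc1NC(=O)c1ccc(OCc2ccccn2)cc1` has not yet been measured. It differs from compound 3 in one place: pyridin-2-yl in place of 1-methyl-1H-imidazol-4-yl on an aromatic carbon. In words, pyridin-2-yl stands in place of 1-methyl-1H-imidazol-4-yl on an aromatic carbon.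

Going by the values given here, two measured steps bear on this, though only loosely. One is a number 0.20 log units higher from compound 1 to compound 2 (within the scatter), for methyl in place of hydrogen on an aromatic carbon. The other is a number 0.10 log units lower from compound 1 to compound 3 (within the scatter), for methyl in place of chloro on an aromatic carbon. Among the compounds with values here, both are small edits, while the new change exchanges a whole aromatic ring, and no measured pair shows such an exchange. The entering group also counts fewer hydrogen-bond acceptors than the one it replaces.

On that judgement, an upward step beyond the scatter is expected, a number 0.80 log units higher from compound 3 to compound 4 (beyond the scatter). The estimate for compound 4 is 3.8, with an expected range from 3.3 to 4.4.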

Compound 4, distribution coefficient: > 3
Compound 4: no number, only a limit (the forecaster's own chance of this, stated with the estimate: 3%); the middle value does not contradict the limit.
By their numbers in this assay, from the lowest: compounds 3, 1 and 2 (each within the scatter of the next).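

In this assay compound 4 gives > 3, which is a limit of the assay and not a number. The exchange of 1-methyl-1H-imidazol-4-yl for pyridin-2-yl is the only swap of a whole aromatic ring shown at this place, on an aromatic carbon para to a methyl group, and what can be read of it is a number no lower from compound 3 to compound 4 (the limit leaves the size open). The result therefore gives this ring exchange a direction that excludes a fall, but no size, and compound 4 is the only compound shown without a number: the limit of > 3 in this assay, at which 1 of the 4 values shown sits.

As far as these compounds go, the real size of the step from the five-membered aromatic ring to the six-membered one remains open, and only a number for compound 4 could settle it. Also open, from the compounds shown here alone, is how this assay would respond at this same place to a group of another kind, such as an amine or a carboxylic acid, or to pyridin-2-yl on the chloro-bearing compound 1.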